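The source may hold more compounds than are shown below. What is called first, only, known or untested is meant among the compounds shown, and "the series" means these compounds.

Measured so far:
- compound 1, `CCCc1cc(C(=O)OCC)c(NC(=O)C2CCN(C(C)=O)CC2)s1`: 7800 nM
- compound 2, `COC(=O)c1cc(C)sc1NC(=O)C1CCN(C(C)=O)CC1`: 8200 nM

Both numbers come from an assay for displacement of a labelled ligand from DNA repair protein REV1 (Homo sapiens), read by fluorescence polarization, with a stated time of 1 h; on this read-out lower numbers stand for tighter binding and higher numbers for weaker binding. In this assay compound 1 gives 7800 nM and compound 2 gives 8200 nM; the two values lie within the scatter of each other, so neither compound can be set apart from the other on the numbers shown. Going by the values given here, compound 2 thus stands together with compound 1 in the weak range, with no step between the two that could be read as a real difference.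

The next compound, compound 3, `CCc1cc(C(=O)OC)c(NC(=O)C2CCN(C(C)=O)CC2)s1`, has not yet been measured in this assay. It differs from compound 2 by methyl in place of hydrogen on a saturated chain carbon bound to an aromatic carbon. Among the compounds with values here, no step between measured compounds of this kind is known, so nothing among the measured numbers argues for a change in either direction beyond the scatter. The expectation for compound 3 is therefore a value near that of compound 2, with the step from compound 2 to compound 3 estimated as a 1.1-fold lower number from compound 2 to compound 3 (0.04 log units; within the scatter). Compound 3 is estimated at 7500 nM, with a range from 3500 nM to 16000 nM.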

Compound 3, dissociation constant: 23700 nM
Beside the measured number, compound 3's estimate is 3.2-fold (0.50 log units) below it, and the stated range ends below it.
By their numbers in this assay, from the lowest: compounds 1 and 2 (each within the scatter of the next); then compound 3.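

In this assay, going by these compounds alone, the methyl to ethyl change gives a 2.9-fold higher number from compound 2 to compound 3 (0.46 log units; beyond the scatter) and is the only step that can be read on a single change. It shows that binding responds to one added methyl on this saturated chain carbon bound to an aromatic carbon, and that on this pair the added carbon goes with weaker binding, though the step is modest. Within the data shown here, nothing measured here accounts for the step, and a single pair cannot show whether it reflects this position in general or only this change on the methyl ester.

Compound 1 carries a propyl chain at this place but also an ethyl ester, so it differs from compound 3 in more than one place and cannot be used to follow the chain on its own. Still open, as far as these compounds go, is how a longer chain such as butyl, an amine or a carboxylic acid at this position would compare with the methyl of compound 2, and whether the ester group changes the response to the chain.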